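The source may hold more compounds than are shown below. What is called first, only, known or untested is meant among the compounds shown, and "the series" means these compounds.

Measured compounds in a functional assay on HeLa cells (Homo sapiens) for inhibition, read by MTT assay, with a stated time of 24 h; on this read-out lower numbers stand for stronger inhibition and higher numbers for weaker inhibition:
compound 1, `CCOC(=O)C1=Cc2ccccc2OC1(OCc1cn(CC(=O)NC2CCCCC2)nn1)C(F)(F)F`: 11400 nM
compound 2, `CCOC(=O)C1=Cc2ccccc2OC1(OCc1cc(-c2ccc([N+](=O)[O-])cc2)no1)C(F)(F)F`: > 150000 nM

Among the measured compounds shown here, compound 1 holds the only number obtained in this assay. The value of compound 2 is a limit of this assay, not a number. Compound 2 sits at the limit of > 150000 nM in this assay, at which 1 of the 2 values shown sits. Compound 3, `CCOC(=O)C1=Cc2ccccc2OC1(OCc1cn(CC(=O)Nc2ccc(I)cc2Cl)nn1)C(F)(F)F`, is not yet measured. It differs from compound 1 by 2-chloro-4-iodophenyl in place of cyclohexyl on an amide-type nitrogen. For the measured compounds named here, no measured pair in the set isolates a change of this kind, so the size of the step is open. A moderate step toward lower numbers is expected, a 1.6-fold lower number from compound 1 to compound 3 (0.21 log units; within the scatter), with wide uncertainty. Compound 3 is estimated at 7000 nM, within 2000 nM to 30000 nM.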

Compound 3, half-maximal inhibitory concentration: 26100 nM
For compound 3 the middle estimate is 3.7-fold (0.57 log units) below the measured one, and the stated range covers the measured number.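

On the amide-type nitrogen, 2-chloro-4-iodophenyl in place of cyclohexyl gives a 2.3-fold higher number from compound 1 to compound 3 (0.36 log units; beyond the scatter) in this assay. This position therefore responds to the substituent, and this halogenated aromatic ring does not improve on the cyclohexyl ring. Nothing available accounts for the step.

Among the compounds shown here, with only this pair, the effect of the aromatic ring cannot be separated from that of the chlorine or the iodine. On these data alone, how an unsubstituted phenyl, a 4-chlorophenyl, or a cyclohexyl ring carrying an amine or a carboxylic acid would compare at this position remains open.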